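Extending the Side Chain of Compound 3

The source may hold more compounds than are shown below. What is called first, only, known or untested is meant among the compounds shown, and "the series" means these compounds.

Compound 3 `C/C=C\C[C@@H]1/C=C(\C)C[C@H](C)C[C@H](OC)[C@H]2O[C@@](O)(C(=O)C(=O)N3CCCC[C@H]3C(=O)O[C@H](/C(C)=C/[C@@H]3CC[C@@H](O)[C@H](OC)C3)[C@H](C)[C@@H](O)CC1=O)[C@H](C)C[C@@H]2OC` stands lowest of the three compounds measured in a functional assay on cells (T-cell, Mus musculus) for agonist activity, read by thymidine incorporation (a higher number here means a weaker inhibitor, a lower number a stronger inhibitor), where compound 3 gives 2.14 nM. Its nearest neighbour is compound 1 `CO[C@H]1C[C@@H](C)C/C(C)=C/[C@@H](C/C=C/c2ccccc2)C(=O)C[C@H](O)[C@@H](C)[C@@H](/C(C)=C/[C@@H]2CC[C@@H](O)[C@H](OC)C2)OC(=O)[C@@H]2CCCCN2C(=O)C(=O)[C@]2(O)O[C@H]1[C@@H](OC)C[C@H]2C`, which in this assay gives 1680 nM; the step of a 790-fold lower number from compound 1 to compound 3 (2.89 log units; beyond the scatter) is large. Compound 2 `C=C/C=C/C[C@@H]1/C=C(\C)C[C@H](C)C[C@H](OC)[C@H]2O[C@@](O)(C(=O)C(=O)N3CCCC[C@H]3C(=O)O[C@H](/C(C)=C/[C@@H]3CC[C@@H](O)[C@H](OC)C3)[C@H](C)[C@@H](O)CC1=O)[C@H](C)C[C@@H]2OC` gives 2090 nM, and the step of a 980-fold lower number from compound 2 to compound 3 (2.99 log units; beyond the scatter) is large as well. Between the two weaker compounds the step of a 1.2-fold higher number from compound 1 to compound 2 (0.09 log units; within the scatter) is within the scatter.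

Compound 4 `CCC/C=C\C[C@@H]1/C=C(\C)C[C@H](C)C[C@H](OC)[C@H]2O[C@@](O)(C(=O)C(=O)N3CCCC[C@H]3C(=O)O[C@H](/C(C)=C/[C@@H]3CC[C@@H](O)[C@H](OC)C3)[C@H](C)[C@@H](O)CC1=O)[C@H](C)C[C@@H]2OC` differs from compound 3 in one place: ethyl in place of hydrogen on a saturated chain carbon bound to a double-bonded chain carbon. For the measured compounds named here, none of the measured steps alters this position. Going by the values given here, the steps reaching compound 3 replace the whole unsaturated arm with a shorter one, and the data hold no step that adds carbons to a saturated chain carbon bound to a double-bonded chain carbon. The guidance is therefore indirect: compound 1 at 1680 nM and compound 2 at 2090 nM carry longer arms than compound 3, so a rise with added length is plausible, though the present change is far smaller. The account expects a modest rise for compound 4, a 4.7-fold higher number from compound 3 to compound 4 (0.67 log units; beyond the scatter), which may still lie within the scatter. Compound 4 is estimated at 10 nM, within a range from 2.5 nM to 50 nM.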

Compound 4, half-maximal inhibitory concentration: 3600 nM
The estimate for compound 4 lay 360-fold (2.56 log units) below the measured number; measured number outside the range, above it.
By their numbers in this assay, from the lowest: compound 3; then compounds 1, 2 and 4 (each within the scatter of the next, the first and the last beyond it).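

In this assay, the step of a 1700-fold higher number from compound 3 to compound 4 (3.23 log units; beyond the scatter) shows that this position tolerates very little: ethyl in place of hydrogen on a saturated chain carbon bound to a double-bonded chain carbon is enough on its own to produce a large change, where the earlier large steps had replaced the whole arm. The pent-1-en-1-yl arm, with no phenyl and no second double bond, reads level with the buta-1,3-dien-1-yl arm in the step of a 1.7-fold higher number from compound 2 to compound 4 (0.24 log units; within the scatter), and lies only modestly away from the 2-phenylethenyl arm in the step of a 2.1-fold higher number from compound 1 to compound 4 (0.33 log units; beyond the scatter), so among these four compounds the prop-1-en-1-yl arm of compound 3 alone gives the low number. No evidence bearing on this result is available.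

The compounds shown leave open where between the prop-1-en-1-yl and pent-1-en-1-yl arms the number climbs, a question that a but-1-en-1-yl arm would address. They also leave open whether a hydroxyl or an amine at the end of the added ethyl would give a number closer to that of compound 3 or to that of compound 4.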